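Replacing the amide 3-ethylphenyl group with pyrimidin-5-yl

This account rests on a few compounds, and the source may have more. Where it says the series, first, only, none or still open, it means among the compounds named here.

Measured in an assay on cells for antagonist activity at D(4) dopamine receptor (Homo sapiens), read by luminescence and beta-arrestin recruitment, with a stated time of 90 min; a higher number here means a weaker inhibitor, a lower number a stronger inhibitor:
compound 1 `CCc1cccc(NC(=O)CN2CCN(c3ccccn3)CC2)c1`: 370 nM
compound 2 `Cc1cccc(NC(=O)CCN2CCN(c3ccccn3)CC2)c1`: 1090 nM
compound 3 `CCc1cccc(NC(=O)CN2CCN(c3ccc(Cl)cn3)CC2)c1`: 10400 nM

Compound 3 gives the highest number of the three, with its steps to compound 2 and compound 1 both beyond the scatter. For the measured compounds named here, the one single-place step on record is a 28-fold higher number from compound 1 to compound 3 (1.45 log units; beyond the scatter); it concerns the pyridine ring, not the amide aryl group. Going by the values given here, compound 1 and compound 2 differ in two places, so their values show only that compound 2 returns the higher number.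

Compound 4 `O=C(CN1CCN(c2ccc(Cl)cn2)CC1)Nc1cncnc1` carries pyrimidin-5-yl in place of 3-ethylphenyl on an amide-type nitrogen. Among the compounds with values here, no measured step touches the amide aryl group, so no direct precedent exists for this change. Given that compound 3 already stands highest, the expectation is a modest further rise, a 1.9-fold higher number from compound 3 to compound 4 (0.28 log units; within the scatter). Compound 4 is therefore estimated at 20000 nM, with a range from 6000 nM to 70000 nM.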

Compound 4, half-maximal inhibitory concentration: > 100000 nM
Compound 4 ended at the assay's limit (the forecaster's own chance of this, stated with the estimate: 35%); at least 5.0-fold (0.69 log units) between middle value and limit.
By their numbers in this assay, from the lowest: compound 1; then compound 2; then compound 3. At a limit, above all of these: compound 4.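

In this assay compound 4 gives > 100000 nM, a limit of the assay and not a number. Pyrimidin-5-yl in place of 3-ethylphenyl on an amide-type nitrogen brings an at least 9.6-fold higher number from compound 3 to compound 4 (0.98 log units; beyond the scatter), the only measured step at this position, so the amide aryl group clearly affects the read-out in this chloro-substituted series. The step has only a lower bound, set by compound 4 sitting at: the limit of > 100000 nM in this assay, at which 1 of the 4 values shown sits.

The compounds shown do not separate the removal of the ethyl group from the entry of the ring nitrogens; unsubstituted phenyl or pyridin-3-yl on the amide would address this. Going by these compounds, whether the same change behaves alike on the unchlorinated core of compound 1 also remains open.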